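This account rests on a few compounds, and the source may have more. Where it says the series, first, only, none or still open, it means among the compounds named here.

Working notes on the series. In a functional assay on CAPAN-1 cells (Homo sapiens) for antiproliferative activity, with a stated time of 72 h (on this read-out higher numbers stand for weaker inhibition and lower numbers for stronger inhibition), compound 2 (`Nc1ncnn2c([C@@H]3O[C@H](CO)[C@@H](O)[C@H]3O)cc(-c3ccc(F)cc3)c12`) gives 65600 nM and stands highest of the two numbers in hand, with compound 1 (`CCCC#Cc1cc([C@@H]2O[C@H](CO)[C@@H](O)[C@H]2O)n2ncnc(N)c12`) at 20 nM on the low side. Compound 3 (`Nc1ncnn2c([C@@H]3O[C@H](CO)[C@@H](O)[C@H]3O)cc(-c3ccsc3)c12`) carries thiophen-3-yl in place of 4-fluorophenyl on an aromatic carbon. Within the data shown here, one measured step bears on this place, pent-1-yn-1-yl giving way to 4-fluorophenyl (a 3300-fold higher number from compound 1 to compound 2 (3.52 log units; beyond the scatter)), and it was large. Among the measured compounds shown here, no measured step compares two aromatic rings here, so its size guides only loosely. An aromatic ring stays on this carbon, so a return to the level of compound 1 (20 nM) is not expected. From the high position of compound 2 at 65600 nM a moderate step to a lower number in this assay is expected (an 11-fold lower number from compound 2 to compound 3 (1.04 log units; beyond the scatter)) with wide uncertainty. For compound 3 the expected value is 6000 nM with a range of 400 nM to 60000 nM for now.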

Compound 3, half-maximal inhibitory concentration: 56200 nM
Compound 3: middle estimate off by 9.4-fold (0.97 log units), on the low side; the measured number falls inside the stated range.
By their numbers in this assay, from the lowest: compound 1; then compounds 3 and 2 (each within the scatter of the next).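

In this assay, thiophen-3-yl in place of 4-fluorophenyl on this aromatic carbon gives a 1.2-fold lower number from compound 2 to compound 3 (0.07 log units; within the scatter) and so separates the two rings no further, despite the change from a six-membered ring of carbon only to a five-membered ring with a sulfur. The large gap to the alkyne is therefore not tied to 4-fluorophenyl alone, since thiophen-3-yl in place of pent-1-yn-1-yl gives a 2800-fold higher number from compound 1 to compound 3 (3.45 log units; beyond the scatter) with both aromatic rings reading alike. Nothing measured on these compounds accounts for this result.

On these data alone, it stays open whether the low number of compound 1 depends on the triple bond, the length of the chain, or simply the absence of an aromatic ring at this position. A saturated pentyl chain, a shorter propynyl group or a pyridin-3-yl ring on the same carbon would bear on these possibilities.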